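A few compounds are considered here, and "the series" means these few. Any claim that something is new, unique, unknown or untested is made for them only; others in the source may bear on it.

Compound 1 `COC(=O)c1ccc(NCc2cncn2Cc2ccccc2Cl)cc1-c1ccccc1` gives 10000 nM in a toxicity assay on NIH3T3 cells (Mus musculus) for cytotoxicity, read by resazurin assay; on this read-out lower numbers stand for an effect already at smaller amounts and higher numbers for an effect only at larger amounts of compound. Compound 2 `COC(=O)c1ccc(NCc2cncn2Cc2ccc(C)cc2)cc1-c1ccccc1` gives 50000 nM in this assay. Compound 3 `COC(=O)c1ccc(NCc2cncn2Cc2cccc(F)c2)cc1-c1ccccc1` gives only a limit in this assay, > 1000 nM.

Compound 3 thus stands at a limit rather than at a number, marked by the limit of > 1000 nM in this assay, at which 1 of the 3 values shown sits. The steps a step that the limit leaves unreadable from compound 1 to compound 3 and a step that the limit leaves unreadable from compound 2 to compound 3 therefore cannot be read in size. Compound 4 `COC(=O)c1ccc(NCc2cncn2Cc2ccccc2C#N)cc1-c1ccccc1` differs from compound 3 by 2-cyanophenyl in place of 3-fluorophenyl on a saturated chain carbon bound to an aromatic nitrogen. Among the compounds with values here, no measured step touches a 2-cyanophenyl group; the only step readable in size, a 5.0-fold higher number from compound 1 to compound 2 (0.70 log units; beyond the scatter), shows that exchanging the group on this carbon shifts the number by a modest amount. Compound 4 is expected to give about 10000 nM in this assay, with a range from 3000 nM to 50000 nM. For compound 4 this estimate means an expected step that the limit leaves unreadable from compound 3 to compound 4.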

Compound 4, half-maximal effective concentration: 25000 nM
Beside the measured number, compound 4's estimate is 2.5-fold (0.40 log units) below it; low and high end bracket the measured number.
By their numbers in this assay, from the lowest: compound 1; then compounds 4 and 2 (each within the scatter of the next).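

In this assay, the exchange of chloro for cyano on an aromatic carbon gives a 2.5-fold higher number from compound 1 to compound 4 (0.40 log units; beyond the scatter), which shows that this one group alone can shift the number by a modest amount. The comparison of 2-cyanophenyl with 4-methylphenyl on a saturated chain carbon bound to an aromatic nitrogen gives a 2.0-fold lower number from compound 2 to compound 4 (0.30 log units; within the scatter), so these two groups cannot be told apart here. Compound 3 has only a limit, and its steps cannot be read in size: the limit of > 1000 nM in this assay, at which 1 of the 4 values shown sits.

As far as these compounds go, what an amine or a carboxylic acid on this phenyl ring would do remains open. The compounds shown also leave open the effect of a longer chain in place of the benzyl link.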